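A Thiophen-3-yl in Place of Phenyl at the Carbonyl

The source may hold more compounds than are shown below. What is called first, only, known or untested is meant among the compounds shown, and "the series" means these compounds.

Three compounds sharing one core have been measured in a functional assay on H184B5F5/M10 cells (Homo sapiens) for antiproliferative activity, read by XTT assay, with a stated time of 72 h; a lower number here means a stronger inhibitor, a higher number a weaker inhibitor:

Compound 1 `COc1ccc(-c2cc3ccccc3nc2/C=C/C(=O)c2ccccc2)cc1` gives 8560 nM.
Compound 2 `COc1ccc(-c2cc3ccccc3nc2/C=C/C(=O)c2ccc([N+](=O)[O-])cc2)cc1` gives 6100 nM.
Compound 3 `COc1ccc(-c2cc3ccccc3nc2/C=C/C(=O)c2ccccn2)cc1` gives 4140 nM.

Compound 1 gives the highest of the three numbers; the step of a 1.4-fold lower number from compound 1 to compound 2 (0.15 log units; within the scatter) stays within the scatter, while the step of a 2.1-fold lower number from compound 1 to compound 3 (0.32 log units; beyond the scatter) is modest but beyond it. The step of a 1.5-fold lower number from compound 2 to compound 3 (0.17 log units; within the scatter) is again within the scatter.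

Compound 4 `COc1ccc(-c2cc3ccccc3nc2/C=C/C(=O)c2ccsc2)cc1` has not been measured. It differs from compound 1 in one place: thiophen-3-yl in place of phenyl on a carbonyl carbon. The measured step that bears most on this change is the exchange of the aryl group on the carbonyl carbon, a 2.1-fold lower number from compound 1 to compound 3 (0.32 log units; beyond the scatter), where a heteroaromatic ring replaced phenyl and lowered the number modestly. Compound 4 carries a smaller heteroaromatic ring in the same place, so a similar or smaller movement is expected in this assay, downward if anything. For compound 4 the number is therefore estimated at 6500 nM, within 3000 nM to 15000 nM, which corresponds to an expected step of a 1.3-fold lower number from compound 1 to compound 4 (0.12 log units; within the scatter).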

Compound 4, half-maximal inhibitory concentration: 6390 nM
Estimate against measurement, compound 4: 1.0-fold (0.01 log units) above; the measured number falls inside the stated range.
By their numbers in this assay, from the lowest: compounds 3, 2, 4 and 1 (each within the scatter of the next, the first and the last beyond it).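

In this assay the position on the carbonyl carbon accepts a five-membered aromatic ring with sulfur about as well as the six-membered rings seen so far, since each of the three new steps stays within the scatter (a 1.3-fold lower number from compound 1 to compound 4 (0.13 log units; within the scatter); a 1.0-fold higher number from compound 2 to compound 4 (0.02 log units; within the scatter); a 1.5-fold higher number from compound 3 to compound 4 (0.19 log units; within the scatter)). Compound 4 therefore cannot be told apart from any of the other three compounds, even though compound 1 and compound 3 are separated by more than the scatter. Nothing available explains why these exchanges move the number so little.

The compounds shown leave open how a saturated group on the carbonyl carbon, such as cyclohexyl or a short alkyl chain, would compare with these aromatic rings. They also leave open what an amine or a carboxylic acid on the ring would do.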